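The source may report more compounds than this note shows. Statements on the series, on what has been measured and on what is new or still open speak of the compounds shown alone.

Measured compounds in an ADME assay on cells (Rhabdomyosarcoma cell, Homo sapiens) for cytotoxicity, read by MTT assay, with a stated time of 72 h; on this read-out lower numbers stand for higher toxicity in this test and higher numbers for lower toxicity in this test:
compound 1, `Clc1ccccc1/C=N/c1sc2c(c1-c1nc3ccccc3s1)CCC2`: 123 ug/mL
compound 2, `Clc1ccc(/C=N/c2sc3c(c2-c2nc4ccccc4s2)CCC3)c(Cl)c1`: 160 ug/mL
compound 3, `C(=C/c1ccccc1)\C=N\c1sc2c(c1-c1nc3ccccc3s1)CCCC2`: 207 ug/mL

Compound 2 is compound 1 with chloro in place of hydrogen on an aromatic carbon; this step gave a 1.3-fold higher number from compound 1 to compound 2 (0.11 log units; within the scatter). Compound 3 carries another core; the difference between the core of compound 1 and the core of compound 3 is not broken down here. Its number lies within the scatter of both compound 1 and compound 2, so no order among the three is claimed.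

Compound 4, `Clc1ccc2sc(-c3c(/N=C/C=C/c4ccccc4)sc4c3CCCC4)nc2c1`, is compound 3 with chloro in place of hydrogen on an aromatic carbon. This is the same kind of change as that from compound 1 to compound 2, but the surroundings differ: in compound 2 the chloro enters on a six-membered aromatic ring of carbon only, meta to a chloro group and para to a large group, whereas in compound 4 it enters on such a ring that is part of a fused or bridged system of two rings, meta to a fused ring and para to a fused ring. For the measured compounds named here, the step expected here is a 1.2-fold higher number from compound 3 to compound 4 (0.06 log units; within the scatter), which rests on the single measured step of this kind, a 1.3-fold higher number from compound 1 to compound 2 (0.11 log units; within the scatter), a step within the scatter. For compound 4 the estimate in this assay is 240 ug/mL, expected to fall between 130 ug/mL and 420 ug/mL.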

Compound 4, half-maximal cytotoxic concentration: 212 ug/mL
Beside the measured number, compound 4's estimate is 1.1-fold (0.05 log units) above it; the measured number falls inside the stated range.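

In this assay, chloro in place of hydrogen on an aromatic carbon gives a 1.0-fold higher number from compound 3 to compound 4 (0.01 log units; within the scatter). Set beside the earlier step, the two cores show no difference in how this change reads: the same change on two cores in this assay, a 1.3-fold higher number (0.11 log units; within the scatter) from compound 1 to compound 2 and a 1.0-fold higher number (0.01 log units; within the scatter) from compound 3 to compound 4, 1.3-fold (0.10 log units) apart, within the scatter of two such steps

For the compounds shown here, on both cores the step stays within the scatter, so the pair fits a change that leaves this read-out unmoved, but it does not show that chloro has no effect in general, and with only two steps, and the chloro entering on a different kind of ring in each, it gives no rule for a further core.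

Going by these compounds, it remains open whether any substituent on these aromatic rings can move the number beyond the scatter, for example an amine, a carboxylic acid or a methoxy group in place of the chloro. On these data alone, it is also open whether the same flat result would appear for chloro at another place on the ring of compound 4, or in a different cell line.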